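Chloro in place of hydrogen on compound 1

The source may hold more compounds than are shown below. What is called first, only, known or untested is meant among the compounds shown, and "the series" means these compounds.

Within the data shown here, in a functional assay on HepG2 cells (Homo sapiens) for inhibition, read by MTT assay, with a stated time of 48 h (a lower number here means a stronger inhibitor of growth, a higher number a weaker inhibitor of growth), compound 1 (`Cn1cc(C2CC(c3ccccc3)=NN2C(=O)c2cccnc2)c2ccccc21`) gives 4630 nM and compound 2 (`COc1ccc(C(=O)N2N=C(c3ccccc3)CC2c2cn(C)c3ccccc23)cn1`) gives 3130 nM as its value, so compound 1 cannot be told apart from the only other measured compound. Compound 3 (`Cn1cc(C2CC(c3ccccc3)=NN2C(=O)c2cccnc2Cl)c2ccccc21`) is compound 1 with chloro in place of hydrogen on an aromatic carbon, next to the ring nitrogen (chloro in place of hydrogen on an aromatic carbon). Among the measured compounds shown here, the one measured step that bears on this puts methoxy in place of hydrogen, and a 1.5-fold lower number from compound 1 to compound 2 (0.17 log units; within the scatter) is all it shows. For the measured compounds named here, no measured step involves chloro, so the step expected in this assay stays within the scatter, with a 1.2-fold lower number from compound 1 to compound 3 (0.06 log units; within the scatter) as the estimate. Compound 3 is expected at 4000 nM with a range of 1800 nM to 9000 nM as its estimate.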

Compound 3, concentration for 50% growth inhibition: > 10000 nM
Compound 3: no number, only a limit (the forecaster's own chance of this, stated with the estimate: 3%); middle value at least 2.5-fold (0.39 log units) away from the limit.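

In this assay, among these compounds, chloro on an aromatic carbon next to the ring nitrogen gives the first change beyond the scatter, an at least 2.1-fold higher number from compound 1 to compound 3 (0.33 log units; beyond the scatter), so this position is not indifferent to what sits on it. Set against the 6-methoxypyridin-3-yl group, 2-chloropyridin-3-yl also weakens growth inhibition, with an at least 3.1-fold higher number from compound 2 to compound 3 (0.50 log units; beyond the scatter). Compound 3 has only a limit and no number, so both steps give minimum sizes: the limit of > 10000 nM in this assay, at which 1 of the 3 values shown sits.

Going by these compounds, whether fluoro or an amine on this same carbon would also raise the number remains open. So does the true size of either step.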